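Iodo for benzofuranyl on a weakly active nucleoside

The source may report more compounds than this note shows. Statements on the series, on what has been measured and on what is new or still open speak of the compounds shown alone.

Of the compounds shown here, two have been measured in a functional assay on K562 cells (Homo sapiens), read by MTT assay, with a stated time of 72 h; on this read-out higher numbers stand for weaker inhibition and lower numbers for stronger inhibition. Compound 1 `COc1ncnc2c1c(-c1ccco1)cn2[C@@H]1O[C@H](CO)[C@@H](O)[C@H]1O` gives 60 nM in this assay. Compound 2 `Cc1nc(N)c2c(-c3cc4ccccc4o3)cn([C@@H]3O[C@H](CO)[C@@H](O)[C@H]3O)c2n1` gives 15700 nM in this assay, the higher of the two numbers, and the gap between compound 2 and compound 1 lies well beyond the scatter of repeated measurements. Among the compounds with values here, compound 1 and compound 2 differ in more than one place, so no single step between them can be read.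

Compound 3 `Cc1nc(N)c2c(I)cn([C@@H]3O[C@H](CO)[C@@H](O)[C@H]3O)c2n1` has not been measured. It differs from compound 2 in one place: iodo in place of 1-benzofuran-2-yl on an aromatic carbon. Without a measured step of this kind to rest on, the author expects from compound 2 to compound 3 a step of a 2.0-fold lower number from compound 2 to compound 3 (0.29 log units; within the scatter) in this assay, a modest move toward a lower number that may not clear the scatter. For compound 3 in this assay the estimate is 8000 nM, with a range from 1500 nM to 40000 nM.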

Compound 3, half-maximal inhibitory concentration: 5120 nM
The estimate for compound 3 lay 1.6-fold (0.19 log units) above the measured number; low and high end bracket the measured number.
By their numbers in this assay, from the lowest: compound 1; then compound 3; then compound 2.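

In this assay, the exchange at this aromatic carbon gives a 3.1-fold lower number from compound 2 to compound 3 (0.49 log units; beyond the scatter), so the number does not rise when the 1-benzofuran-2-yl, with its two aromatic rings, gives way to a single iodine atom. On this core, then, the fused aromatic group is not needed for the inhibition seen with compound 2, and the lone iodo does better by a step that clears the scatter. Nothing measured here accounts for this step.

Compound 1 differs from compound 2 and from compound 3 in more than one place, so the steps to it cannot be read, and what separates its number from theirs stays unassigned. On these data alone, it also remains open where a chloro, an ethynyl or a phenyl group at this carbon would fall relative to iodo and 1-benzofuran-2-yl.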